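The source may report more compounds than this note shows. Statements on the series, on what has been measured and on what is new or still open speak of the compounds shown alone.

Compound 1, `COc1ccc(C(O)(Cc2ccc(C)cc2)c2cccc3ccccc23)c(OC)c1OC`, and compound 2, `CCOC(=O)CO/N=C(/c1ccc(OC)c(OC)c1OC)c1cccc2ccccc12`, share a core, and both have been tested in a functional assay on A549 cells (Homo sapiens) for inhibition, read by sulforhodamine B assay, with a stated time of 48 h; on this read-out lower numbers stand for stronger inhibition and higher numbers for weaker inhibition. In this assay compound 1 gives 18700 nM, while compound 2 gives 6720 nM. Compound 1 therefore stands as the higher of the two numbers, which on this read-out means the weaker inhibition, and its gap to compound 2 lies beyond the usual scatter of repeated measurements.

The next compound, compound 3, `C=CCC(O)(c1ccc(OC)c(OC)c1OC)c1cccc2ccccc12`, has not yet been measured. It is obtained from compound 1 by a single change: vinyl in place of 4-methylphenyl on a saturated chain carbon, two bonds along the chain from two aromatic carbons and an oxygen on a saturated carbon. A larger ring-bearing group thus gives way to a much smaller open-chain one at the same position. Among the compounds with values here, no pair of measured compounds shows what a change of this kind does in this assay, so the size and direction of the step can only be guessed. A step of modest size, in either direction, or none beyond the scatter, all look plausible, and the expectation here leans slightly toward a lower number.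

Compound 3 is expected to give about 12000 nM, with a likely range from 4000 nM to 40000 nM. That estimate corresponds to an expected step of a 1.6-fold lower number from compound 1 to compound 3 (0.19 log units; within the scatter).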

Compound 3, half-maximal inhibitory concentration: 10700 nM
Estimate against measurement, compound 3: 1.1-fold (0.05 log units) above; low and high end bracket the measured number.
By their numbers in this assay, from the lowest: compounds 2, 3 and 1 (each within the scatter of the next, the first and the last beyond it).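

Within the data shown here, the change of 4-methylphenyl to vinyl is the first single change at this position that can be read in this assay and it comes to a 1.7-fold lower number from compound 1 to compound 3 (0.24 log units; within the scatter) so compound 1 and compound 3 cannot be told apart here. On this saturated chain carbon, a group with a six-membered aromatic ring and 7 heavy atoms and an open-chain group with 2 heavy atoms therefore give numbers that repeated measurements would not separate, which means the ring is not needed to keep the level of inhibition seen with compound 1. Nothing measured beyond these inhibition numbers speaks to why the two compounds match.

A single pair cannot show how far this tolerance reaches: an amine, a carboxylic acid, a longer chain or a plain hydrogen at the same position could still move the number beyond the scatter. On these data alone, it also stays open whether the same change would read alike on a different core or in a different test.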